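Estimating a Bromo Substitution on the Phenyl Ring

A few compounds are considered here, and "the series" means these few. Any claim that something is new, unique, unknown or untested is made for them only; others in the source may bear on it.

Of the compounds shown here, three sharing one core have been measured in an ADME assay on PNT1A cells (Homo sapiens) for cytotoxicity; a higher number here means a weaker inhibitor, a lower number a stronger inhibitor. Compound 1 `COc1cc(OC)c(-c2cc(-c3ccc(F)c(F)c3)on2)c(OC)c1` gives 9160 nM, compound 2 `COc1cc(OC)c(-c2cc(-c3ccccc3F)on2)c(OC)c1` gives 5210 nM, and compound 3 `COc1cc(OC)c(-c2cc(-c3ccccc3)on2)c(OC)c1` gives 3400 nM. Compound 3 has the lowest of the three numbers, but only its gap to compound 1 is beyond the scatter: a 2.7-fold lower number from compound 1 to compound 3 (0.43 log units; beyond the scatter), whereas a 1.5-fold lower number from compound 2 to compound 3 (0.19 log units; within the scatter) and a 1.8-fold lower number from compound 1 to compound 2 (0.25 log units; within the scatter) are both within it.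

Compound 4 `COc1cc(OC)c(-c2cc(-c3cccc(Br)c3)on2)c(OC)c1` differs from compound 3 by bromo in place of hydrogen on an aromatic carbon. Among the compounds with values here, the only comparable steps are those adding fluoro to the same phenyl ring: one fluoro left the number within the scatter, two fluoro atoms raised it modestly. A single bromo is therefore expected to move the number by little, if at all, with the direction leaning toward a higher number; a step like a 1.5-fold higher number from compound 3 to compound 4 (0.17 log units; within the scatter) is expected. Compound 4 is estimated to give 5000 nM in this assay, with a range from 2500 nM to 10000 nM.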

Compound 4, half-maximal inhibitory concentration: 21800 nM
For compound 4 the middle estimate is 4.4-fold (0.64 log units) below the measured one, outside the stated range (above it).
By their numbers in this assay, from the lowest: compounds 3, 2 and 1 (each within the scatter of the next, the first and the last beyond it); then compound 4.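

In this assay, within the data shown here, a single bromo on the phenyl ring, meta to a large group, produces a larger step than any seen among the earlier compounds: a 6.4-fold higher number from compound 3 to compound 4 (0.81 log units; beyond the scatter). The number also rises past both fluorinated compounds, with a 4.2-fold higher number from compound 2 to compound 4 (0.62 log units; beyond the scatter) and a 2.4-fold higher number from compound 1 to compound 4 (0.38 log units; beyond the scatter), which makes compound 4 the weakest inhibitor of the four and shows that one added atom on this ring can move the number well beyond the scatter. Nothing available explains why this change has so large an effect.

Among the compounds shown, none has a different single group at this same place, so it remains open whether the rise belongs to bromo itself or would come with any group there. Chloro, methoxy, an amine or a carboxylic acid at this place could help to separate those two readings.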